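Swapping bromo for cyano: clearance in two related series

The compounds below may be only part of what the source reports. "The series", "measured", "known", "first", "only" and "open" are said of these compounds alone.

Compound 1 `COc1cc([C@](O)(CCN(C)C)[C@@H](c2cc3cc(Br)ccc3nc2OC)c2ccnc(OC)c2OC)cc(OC(F)F)n1` and compound 2 `COc1cc([C@](O)(CCN(C)C)[C@@H](c2cc3cc(C#N)ccc3nc2OC)c2ccnc(OC)c2OC)cc(OC(F)F)n1` share one core and differ in a single place: cyano in place of bromo on an aromatic carbon. In an ADME assay on the whole organism (Mus musculus, strain CD-1) for pharmacokinetics (on this read-out lower numbers stand for slow clearance and higher numbers for fast clearance), compound 1 gives 8.7 mL/min/kg, while compound 2 gives 24 mL/min/kg, so the change brought a 2.8-fold higher number from compound 1 to compound 2 (0.44 log units; beyond the scatter).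

Compound 3 `COc1cccc([C@H](c2cc3cc(Br)ccc3nc2OC)[C@@](O)(CCN(C)C)c2cc(SC)nc(SC)c2)c1F` is built on a different core; the difference between the two cores is not broken down here. In this assay compound 3 gives 13 mL/min/kg, which sits within the scatter of compound 1 and of compound 2.

Compound 4 `COc1cccc([C@H](c2cc3cc(C#N)ccc3nc2OC)[C@@](O)(CCN(C)C)c2cc(SC)nc(SC)c2)c1F` is made from compound 3 by the same change: cyano in place of bromo on an aromatic carbon. Among the compounds with values here, the substituent sits in the same surroundings in both pairs, so the step seen from compound 1 to compound 2 is the only guide available. On that basis compound 4 is expected to show a 2.5-fold higher number from compound 3 to compound 4 (0.39 log units; beyond the scatter), since the step in the first pair was a 2.8-fold higher number from compound 1 to compound 2 (0.44 log units; beyond the scatter). The estimate for compound 4 is therefore 32 mL/min/kg, with a likely range from 14 mL/min/kg to 70 mL/min/kg, the width reflecting that this change has been seen only once before.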

Compound 4, clearance: 44 mL/min/kg
For compound 4 the middle estimate is 1.4-fold (0.14 log units) below the measured one, and the stated range covers the measured number.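

On the core of compound 3, putting cyano in place of bromo gave a 3.4-fold higher number from compound 3 to compound 4 (0.53 log units; beyond the scatter) in this assay, so clearance went up on this core just as it did on the core of compound 1. The change therefore carried over from one core to the other in both direction and size, and the two steps cannot be told apart: the same change on two cores in this assay, a 2.8-fold higher number (0.44 log units; beyond the scatter) from compound 1 to compound 2 and a 3.4-fold higher number (0.53 log units; beyond the scatter) from compound 3 to compound 4, 1.2-fold (0.09 log units) apart, within the scatter of two such steps. Within the data shown here, this rests on only two matched pairs, so it shows that the step held between these two cores, but it does not show that it would hold on every core, and it does not explain why clearance goes up.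

The compounds shown leave open whether another group on the same aromatic carbon, such as chloro, methyl or a carboxylic acid, would give a step like this one or a different one. They also leave open how large the step from bromo to cyano would be on a third core.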